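Cytotoxicity notes: aryl swap on the triazole nitrogen

The source may hold more compounds than are shown below. What is called first, only, known or untested is meant among the compounds shown, and "the series" means these compounds.

Measured so far:
compound 1 `Oc1cc(C(F)(F)F)ccc1-c1nc(-c2ccccc2O)n(-c2cccc(C(F)(F)F)c2)n1` — 99.9%
compound 2 `Cc1ccc(-n2nc(-c3ccc(C(F)(F)F)cc3O)nc2-c2ccccc2O)c(C)c1` — 106%

In a functional assay on PC-12 cells (Rattus norvegicus) for cytotoxicity, read by MTT assay, with stated times of 2 h and 24 h, tested at 10 uM (a lower number here means a weaker effect, a higher number a stronger effect of the compound at the concentration tested), compound 2 stands highest of the two numbers, with compound 1 nearest; the step of a number 6.1 percentage points higher from compound 1 to compound 2 (within the scatter) is within the scatter. Compound 3 `Oc1cc(C(F)(F)F)ccc1-c1nc(-c2ccccc2O)n(-c2ccc(F)cc2F)n1` differs from compound 2 by 2,4-difluorophenyl in place of 2,4-dimethylphenyl on an aromatic nitrogen. Among the measured compounds shown here, the only step known, from compound 1 to compound 2, also changed this group on the same nitrogen and moved the read-out little, so no step beyond the scatter is expected in this assay here, a number 4 percentage points lower from compound 2 to compound 3 (within the scatter). For compound 3 the estimate is 102%, expected between 88% and 116%.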

Compound 3, a percentage reported as activity, at one concentration (the size of the read-out at that concentration, not a potency): 97.9%
Beside the measured number, compound 3's estimate is 4.1 percentage points above it, within the range that was stated.
By their numbers in this assay, from the lowest: compounds 3, 1 and 2 (each within the scatter of the next).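

In this assay, 2,4-difluorophenyl in place of 2,4-dimethylphenyl on the aromatic nitrogen gives a number 8.1 percentage points lower from compound 2 to compound 3 (within the scatter), and in place of 3-(trifluoromethyl)phenyl it gives a number 2 percentage points lower from compound 1 to compound 3 (within the scatter). A third aryl group, now bearing fluorine, therefore joins the other two at this position with no step beyond the scatter among compounds 1, 2 and 3. Nothing available explains this flat read-out.

Still open, going by these compounds, is whether an aryl group bearing an amine or a carboxylic acid would move the read-out. A longer alkyl chain on this nitrogen is equally untested here.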